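Dropping One Trifluoromethyl Group: What Three Analogues Suggest

The source may report more compounds than this note shows. Statements on the series, on what has been measured and on what is new or still open speak of the compounds shown alone.

Compound 1 `CN(C(=O)NC(=O)c1ccccc1F)c1nc(C(F)(F)F)c(C(=O)N/N=C/c2cc(C(F)(F)F)cc(C(F)(F)F)c2)s1` gives 6.16 ug/mL.
Compound 2 `CN(C(=O)NC(=O)c1cccc(C(F)(F)F)c1)c1nc(C(F)(F)F)c(C(=O)N/N=C/c2cc(C(F)(F)F)cc(C(F)(F)F)c2)s1` gives 6.08 ug/mL.
Compound 3 `CN(C(=O)NC(=O)c1c(F)cccc1F)c1nc(C(F)(F)F)c(C(=O)N/N=C/c2cc(C(F)(F)F)cc(C(F)(F)F)c2)s1` gives 6.85 ug/mL.

These values come from a functional assay on MCF7 cells (Homo sapiens) for inhibition, read by MTT assay, with a stated time of 72 h; on this read-out lower numbers stand for stronger inhibition and higher numbers for weaker inhibition. Compound 2 has the lowest of the three numbers, yet the others lie close: a 1.0-fold lower number from compound 1 to compound 2 (0.01 log units; within the scatter) and a 1.1-fold higher number from compound 2 to compound 3 (0.05 log units; within the scatter), and likewise a 1.1-fold higher number from compound 1 to compound 3 (0.05 log units; within the scatter). None of these steps is beyond the scatter, so the three compounds cannot be told apart in this assay.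

Compound 4 `CN(C(=O)NC(=O)c1cccc(C(F)(F)F)c1)c1nc(C(F)(F)F)c(C(=O)N/N=C/c2cccc(C(F)(F)F)c2)s1` differs from compound 2 by hydrogen in place of trifluoromethyl on an aromatic carbon. Among the compounds with values here, no measured step touches this part of the structure; the three measured changes all sat on the other carbonyl, and none of them moved the number beyond the scatter. With no evidence for a change at this position, compound 4 is expected to give about 6.5 ug/mL, within a range of 3.2 ug/mL to 13 ug/mL. The expected step is a 1.1-fold higher number from compound 2 to compound 4 (0.03 log units; within the scatter), which is within the scatter.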

Compound 4, half-maximal inhibitory concentration: 3.7 ug/mL
Compound 4: the middle estimate sits 1.8-fold (0.24 log units) above what was measured; the range from low to high includes it.
By their numbers in this assay, from the lowest: compounds 4, 2, 1 and 3 (each within the scatter of the next).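

Taking one trifluoromethyl group off this six-membered aromatic ring gives a 1.6-fold lower number from compound 2 to compound 4 (0.22 log units; within the scatter) in this assay. Within the data shown here, this is the first look at this end of the molecule, since the earlier steps all changed the other carbonyl, and it shows that a group of 4 heavy atoms can give way to hydrogen here without a step beyond the scatter. Nothing among the data explains this result. Still open, on these data alone, is what the remaining trifluoromethyl group contributes. An amine or a carboxylic acid at the emptied position could also give a quite different number.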